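Swapping fluorine for chlorine on a fluorinated benzyl arm

The compounds below may be only part of what the source reports. "The series", "measured", "known", "first", "only" and "open" are said of these compounds alone.

Of the compounds shown here, three that share one core have been tested in a functional assay on MT4 cells (Homo sapiens) for cytotoxicity, read by MTT assay; a lower number here means that less compound is tolerated, a higher number that more compound is tolerated. Compound 1, `COc1ccc(CSc2nc(O)c(C)c(Cc3ccc(F)cc3)n2)cc1`, gives 8900 nM in this assay. Compound 2, `Cc1c(O)nc(SCc2ccc(C#N)cc2)nc1Cc1c(F)cccc1F`, reaches only a limit of the assay in this assay, > 65000 nM, which is the limit of > 65000 nM in this assay, at which 1 of the 3 values shown sits. Compound 3, `COc1cc(CSc2nc(O)c(C)c(Cc3c(F)cccc3F)n2)cc(OC)c1`, likewise reaches only a limit of the assay in this assay, > 60000 nM, which is the limit of > 60000 nM in this assay, at which 1 of the 3 values shown sits. So for compound 3 no number is known, only that the tolerated concentration lies at the edge of what the assay could measure, and the same holds for compound 2; only compound 1 has a real number.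

Compound 4, `COc1cc(CSc2nc(O)c(C)c(Cc3c(Cl)cccc3Cl)n2)cc(OC)c1`, differs from compound 3 in one place: 2,6-dichlorophenyl in place of 2,6-difluorophenyl on a saturated chain carbon bound to an aromatic carbon. Among the measured compounds shown here, no measured pair in this set carries the same change, so there is nothing to lean on beyond compound 3 itself. The expected step from compound 3 to compound 4 is an at least 1.3-fold lower number from compound 3 to compound 4 (0.12 log units; that floor lies within the scatter), a small move toward less tolerated compound, near the scatter of the assay, and it may well come back as a limit again. On that basis compound 4 is estimated at 45000 nM in this assay, within a range from 12000 nM to 100000 nM.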

Compound 4, half-maximal cytotoxic concentration: > 55000 nM
Compound 4: only a limit was reported (the forecaster's own chance of this, stated with the estimate: 50%); middle value at least 1.2-fold (0.08 log units) away from the limit.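

Compound 3 and compound 4 both give only a limit in this assay, not a real number, so the step between them cannot be read. The compounds shown leave open whether 2,6-dichlorophenyl in place of 2,6-difluorophenyl changes the tolerated concentration at all, and if it does, in which direction.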